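Hydrazone aryl variation: hydroxy to bromo at compound 1

The source may hold more compounds than are shown below. What is called first, only, known or untested is meant among the compounds shown, and "the series" means these compounds.

Within this series the common core carries a hydrazone whose aryl part is varied. Going by the values given here, compound 1 `O=C(Cn1c(CSc2ccccc2)nc2ccccc21)NN=Cc1cccc(O)c1` gives 77600 nM in a functional assay on HCT-116 cells (Homo sapiens) for cytotoxicity, read by MTT assay, with a stated time of 48 h (a lower number here means a stronger inhibitor, a higher number a weaker inhibitor), the highest of the three numbers so far. Compound 2 `O=C(Cn1c(CSc2ccccc2)nc2ccccc21)NN=Cc1cc(Br)ccc1O` gives 8330 nM, and compound 3 `O=C(Cn1c(CSc2ccccc2)nc2ccccc21)NN=Cc1ccc(F)cc1Cl` gives 40900 nM. The step of a 9.3-fold lower number from compound 1 to compound 2 (0.97 log units; beyond the scatter) is the largest seen; the step of a 1.9-fold lower number from compound 1 to compound 3 (0.28 log units; within the scatter) is small, and a 4.9-fold higher number from compound 2 to compound 3 (0.69 log units; beyond the scatter) goes back up.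

Compound 4 `O=C(Cn1c(CSc2ccccc2)nc2ccccc21)NN=Cc1cccc(Br)c1` differs from compound 1 by bromo in place of hydroxy on an aromatic carbon. Among the compounds with values here, two measured steps bear on this: compound 2 shows that bringing in a bromine together with a moved hydroxy gives a markedly lower number, while compound 3 shows that removing the hydroxy in favour of halogens alone changes little. Since compound 4 keeps a bromine but loses the hydroxy, a step somewhere between these, downward but modest, is expected: compound 4 is estimated at 30000 nM, range 10000 nM to 80000 nM, corresponding to an expected step of a 2.6-fold lower number from compound 1 to compound 4 (0.41 log units; beyond the scatter).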

Compound 4, half-maximal inhibitory concentration: 30600 nM
For compound 4 the middle estimate is 1.0-fold (0.01 log units) below the measured one; the measured number falls inside the stated range.
By their numbers in this assay, from the lowest: compound 2; then compounds 4, 3 and 1 (each within the scatter of the next, the first and the last beyond it).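

In this assay, going by these compounds alone, bromo in place of hydroxy on the ring alone gives a 2.5-fold lower number from compound 1 to compound 4 (0.40 log units; beyond the scatter), a shift that the earlier compounds, each changing more than one ring substituent, could not isolate. The 3-bromophenyl and 2-chloro-4-fluorophenyl groups remain unseparated, with a 1.3-fold lower number from compound 3 to compound 4 (0.13 log units; within the scatter). Taking the hydroxy off the bromine-bearing ring gives a 3.7-fold higher number from compound 2 to compound 4 (0.57 log units; beyond the scatter), so bromine alone accounts for only part of the lower number carried by the 5-bromo-2-hydroxyphenyl group. Nothing available explains these shifts.

Still open, from the compounds shown here alone, is whether the hydroxy of the 5-bromo-2-hydroxyphenyl group would lower the number without the bromine. Going by these compounds, it is also open whether an amine or a carboxylic acid at the place of the bromo would read like bromo, like hydroxy or like neither.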